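The source may hold more compounds than are shown below. What is called first, only, known or untested is meant among the compounds shown, and "the series" means these compounds.

Measured in a toxicity assay on RAW264.7 cells (Mus musculus) for cytotoxicity, read by MTT assay, with a stated time of 24 h; on this read-out higher numbers stand for weaker inhibition and lower numbers for stronger inhibition:

Compound 1 `C=C[C@@](C)(/C=C/c1ccc(OCc2cn(Cc3ccc(Cl)cc3)nn2)cc1)CCC=C(C)C`: 327000 nM
Compound 2 `C=C[C@@](C)(/C=C/c1ccc(OCc2cn(Cc3ccc(F)cc3)nn2)cc1)CCC=C(C)C`: 157000 nM
Compound 3 `C=C[C@@](C)(/C=C/c1ccc(OCC(=O)Nc2ccc(F)cc2)cc1)CCC=C(C)C`: 59100 nM

Compound 2 and compound 1 share one core and differ by chloro in place of fluoro on an aromatic carbon; the step is a 2.1-fold higher number from compound 2 to compound 1 (0.32 log units; beyond the scatter). Compound 3 carries another core; the difference between the two cores is not broken down here. Compound 3 gives the lowest of the three numbers, with compound 2 nearest and compound 1 furthest.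

Compound 4 `C=C[C@@](C)(/C=C/c1ccc(OCC(=O)Nc2ccc(Cl)cc2)cc1)CCC=C(C)C` is not yet measured. It differs from compound 3 by chloro in place of fluoro on an aromatic carbon, the same change as from compound 2 to compound 1, at the same kind of place. In this assay a step of similar size is expected, a 2.0-fold higher number from compound 3 to compound 4 (0.31 log units; beyond the scatter). Among the measured compounds shown here, this rests on compound 2 and compound 1, whose step a 2.1-fold higher number from compound 2 to compound 1 (0.32 log units; beyond the scatter) is the one comparison available. For compound 4 the estimate is 120000 nM, expected to fall between 50000 nM and 300000 nM.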

Compound 4, half-maximal inhibitory concentration: 50700 nM
The estimate for compound 4 lay 2.4-fold (0.37 log units) above the measured number, within the range that was stated.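

In this assay, chloro in place of fluoro on the core of compound 3 gives a 1.2-fold lower number from compound 3 to compound 4 (0.07 log units; within the scatter). Set beside the same change on the other core, the two steps cannot be told apart: the same change on two cores in this assay, a 2.1-fold higher number (0.32 log units; beyond the scatter) from compound 2 to compound 1 and a 1.2-fold lower number (0.07 log units; within the scatter) from compound 3 to compound 4, 2.4-fold (0.39 log units) apart, within the scatter of two such steps. Among the compounds shown here, this does not establish that the change carries across cores with a fixed size: each core offers a single pair, and only one of the two steps stands beyond the scatter.

Open, on these data alone, is how a bromo, a methoxy or a nitrile in place of the chloro would read on either core. Also open, as far as these compounds go, is whether an amine or a carboxylic acid there would give steps that clearly differ between the two cores.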